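Shifting the nitro group from compound 2 to compound 3

The source may hold more compounds than are shown below. What is called first, only, known or untested is meant among the compounds shown, and "the series" means these compounds.

Compound 1 `O=C1NC(=O)/C(=C/c2ccc(OCCSc3nnc(-c4ccccc4)[nH]3)cc2)S1` gives 26.4% in a functional assay on the whole organism (strain Wistar) with Rattus norvegicus as the target, with a stated time of 15 days, at a dose of 30 mg/kg by the oral route; on this read-out higher numbers stand for a stronger effect at the one dose given and lower numbers for a weaker effect. Compound 2 `O=C1NC(=O)/C(=C/c2ccc(OCCSc3nnc(-c4ccc([N+](=O)[O-])cc4)[nH]3)cc2)S1` gives 18.6% in this assay, within the scatter of compound 1, so the two cannot be ranked. Going by the values given here, the only measured step, a number 7.8 percentage points lower from compound 1 to compound 2 (within the scatter), shows that introducing the nitro group made little difference. Compound 3 `O=C1NC(=O)/C(=C/c2ccc(OCCSc3nnc(-c4ccccc4[N+](=O)[O-])[nH]3)cc2)S1` differs from compound 2 by 2-nitrophenyl in place of 4-nitrophenyl on an aromatic carbon. Among the compounds with values here, no measured step moves a nitro group from one aromatic carbon to another, so the expectation rests on that single small step alone. The step expected for compound 3 is a number 1.4 percentage points higher from compound 2 to compound 3 (within the scatter), nothing beyond the scatter. Compound 3 is therefore estimated at 20%, between 8% and 32%.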

Compound 3, a percentage reported as activity, at one dose (the size of the read-out at that dose, not a potency): 38.6%
For compound 3 the middle estimate is 18.6 percentage points below the measured one; measured number above the stated range.
By their numbers in this assay, from the lowest: compounds 2 and 1 (each within the scatter of the next); then compound 3.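

Moving the nitro group from 4-nitrophenyl to 2-nitrophenyl gives a number 20 percentage points higher from compound 2 to compound 3 (beyond the scatter) in this assay and shows that where the nitro group sits on the phenyl ring matters, which the earlier compounds could not show. Only as 2-nitrophenyl does adding a nitro group to the phenyl ring separate from the unsubstituted compound, with a number 12.2 percentage points higher from compound 1 to compound 3 (beyond the scatter) as the step. Nothing available explains this difference between the two placements.

Still open, on these data alone, is whether an amine or a carboxylic acid on the phenyl ring, in the place the nitro group holds in 2-nitrophenyl, would give a similar number.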